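A Halogen Swap on the Shared Core: Expecting Compound 4

The source may hold more compounds than are shown below. What is called first, only, known or untested is meant among the compounds shown, and "the series" means these compounds.

Of the compounds shown here, three built on one shared core have been measured in an ADME assay on Vero cells (Chlorocebus sabaeus) for cytotoxicity, read by neutral red uptake, tested at 197 ug/mL; on this read-out lower numbers stand for a stronger effect and higher numbers for a weaker effect at the one concentration tested. Compound 1 `O=C1CSC(c2ccc(O)cc2)N1CCN1CCCCC1` gives 87%, compound 2 `COc1ccccc1C1SCC(=O)N1CCN1CCCCC1` gives 72%, and compound 3 `O=C1CSC(c2cccc(F)c2)N1CCN1CCCCC1` gives 84%. Among these three numbers compound 3 stands second highest; compound 1 is its nearest neighbour, and the two lie within the usual scatter of each other, while compound 2 sits further away, with a lower number that is beyond the scatter.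

Compound 4 `O=C1CSC(c2ccccc2Cl)N1CCN1CCCCC1` has not yet been measured. It differs from compound 3 in one place: 2-chlorophenyl in place of 3-fluorophenyl on a saturated ring carbon. Going by the values given here, only one measured step in this set exchanges the aromatic group on that saturated ring carbon, namely a number 3 percentage points lower from compound 1 to compound 3 (within the scatter), a change that stayed within the scatter even though a hydroxyl group was replaced by a fluorine. Among the compounds with values here, no step from compound 2 to any other compound is available, so its lower number can only be noted, not traced to a single change.

With one halogen-bearing phenyl giving way to another, the expected step of a number 3 percentage points lower from compound 3 to compound 4 (within the scatter) is small and within the scatter, and compound 4 is therefore estimated at 81%, within a range from 68% to 92%.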

Compound 4, a percentage reported as activity, at one concentration (the size of the read-out at that concentration, not a potency): 71%
Beside the measured number, compound 4's estimate is 10 percentage points above it; the measured number falls inside the stated range.
By their numbers in this assay, from the lowest: compounds 4 and 2 (each within the scatter of the next); then compounds 3 and 1 (each within the scatter of the next).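

In this assay, the group on the saturated ring carbon can shift the reading beyond the usual scatter: 2-chlorophenyl in place of 3-fluorophenyl gives a number 13 percentage points lower from compound 3 to compound 4 (beyond the scatter), and 2-chlorophenyl in place of 4-hydroxyphenyl gives a number 16 percentage points lower from compound 1 to compound 4 (beyond the scatter), whereas the earlier exchange at this carbon stayed within the scatter. Chloro in place of methoxy on an aromatic carbon gives a number 1 percentage points lower from compound 2 to compound 4 (within the scatter), which lies within the scatter, so the two compounds cannot be told apart here, and the two lowest readings of the set are found with these two groups. No measurement is available that explains these differences.

Compound 3 and compound 4 differ in both the halogen and its place on the phenyl ring, and the compounds shown do not separate these two changes. Going by these compounds, it also remains open how the reading would respond to an amine or a carboxylic acid on that phenyl ring.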